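The source may hold more compounds than are shown below. What is called first, only, known or untested is meant among the compounds shown, and "the series" means these compounds.

Measured in a functional assay on U-937 cells (Homo sapiens) for antiproliferative activity, read by MTT assay, with a stated time of 24 h; on this read-out higher numbers stand for weaker inhibition and lower numbers for stronger inhibition:
- compound 1 `CCCCc1oc2ccccc2c1C(=O)c1ccc(OCC(N)=O)cc1`: 42200 nM
- compound 2 `CCCCNC(=O)COc1ccc(C(=O)c2c(CCCC)oc3ccccc23)cc1`: 22800 nM
- compound 3 `CCCCc1oc2ccccc2c1C(=O)c1ccc(OCC(=O)N2CCCCC2)cc1`: 37100 nM

Compound 3 stands within the scatter of both other measured compounds. The steps that reach it are a 1.1-fold lower number from compound 1 to compound 3 (0.06 log units; within the scatter) and a 1.6-fold higher number from compound 2 to compound 3 (0.21 log units; within the scatter), and the remaining step is a 1.9-fold lower number from compound 1 to compound 2 (0.27 log units; within the scatter).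

Compound 4 `CCCCc1oc2ccccc2c1C(=O)c1ccc(OCC(=O)N2CCOCC2)cc1` has morpholin-4-yl in place of piperidin-1-yl on a carbonyl carbon. All three measured steps change the group on this same carbonyl carbon, and none goes beyond the scatter. No step beyond the scatter is therefore expected in this assay.

The expected change is a 1.0-fold higher number from compound 3 to compound 4 (0.01 log units; within the scatter). For compound 4 the estimated value is 38000 nM, with an expected range of 20000 nM to 75000 nM.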

Compound 4, half-maximal inhibitory concentration: 45400 nM
Compound 4: middle estimate off by 1.2-fold (0.08 log units), on the low side, and the stated range covers the measured number.
By their numbers in this assay, from the lowest: compounds 2, 3, 1 and 4 (each within the scatter of the next).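

In this assay, swapping piperidin-1-yl for morpholin-4-yl on this carbonyl carbon brings in a ring oxygen and a hydrogen-bond acceptor, and the result is a 1.2-fold higher number from compound 3 to compound 4 (0.09 log units; within the scatter). The other two steps to morpholin-4-yl, a 1.1-fold higher number from compound 1 to compound 4 (0.03 log units; within the scatter) and a 2.0-fold higher number from compound 2 to compound 4 (0.30 log units; within the scatter), also stay within the scatter, so amino, butylamino, piperidin-1-yl and morpholin-4-yl are not told apart at this position. Nothing available accounts for these steps.

Still open, on these data alone, is whether a carboxylic acid on this carbonyl carbon, a piperazine ring with a free amine, or a chain longer than butyl would go beyond the scatter.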